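The compounds below may be only part of what the source reports. "The series", "measured", "known", "first", "only" and "open" are said of these compounds alone.

In a functional assay on PC-3 cells (Homo sapiens) for antiproliferative activity, read by MTT assay, with a stated time of 72 h (on this read-out lower numbers stand for stronger inhibition and higher numbers for weaker inhibition), compound 1 `O=C(N/N=C/c1ccc(F)cc1)Nc1ccc(Oc2ccnc3[nH]ccc23)c(F)c1` gives 2330 nM, compound 2 `O=C(N/N=C/c1ccc(F)cc1Cl)Nc1ccc(Oc2ccnc3[nH]ccc23)c(F)c1` gives 3 nM, and compound 3 `O=C(N/N=C/c1ccc(O)cc1O)Nc1ccc(Oc2ccnc3[nH]ccc23)c(F)c1` gives 13000 nM, the highest of the three numbers. Compound 4 `O=C(N/N=C/c1ccc(O)c(Br)c1)Nc1ccc(Oc2ccnc3[nH]ccc23)c(F)c1` has 3-bromo-4-hydroxyphenyl in place of 2,4-dihydroxyphenyl on a carbon with a double bond to nitrogen. For the measured compounds named here, the closest precedent is a 780-fold lower number from compound 1 to compound 2 (2.89 log units; beyond the scatter), where chloro replaces hydrogen on an aromatic carbon. Also relevant are a 5.6-fold higher number from compound 1 to compound 3 (0.75 log units; beyond the scatter) and a 4300-fold higher number from compound 2 to compound 3 (3.64 log units; beyond the scatter), both of which introduce 2,4-dihydroxyphenyl. Going by the values given here, no measured compound carries bromo, so the size remains uncertain. A large step to a lower number in this assay is expected: a 33-fold lower number from compound 3 to compound 4 (1.51 log units; beyond the scatter). The estimate for compound 4 is 400 nM, with an expected range of 15 nM to 5000 nM.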

Compound 4, half-maximal inhibitory concentration: 28600 nM
Compound 4: middle estimate off by 72-fold (1.85 log units), on the low side, and the stated range ends below it.
By their numbers in this assay, from the lowest: compound 2; then compound 1; then compound 3; then compound 4.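

In this assay, 3-bromo-4-hydroxyphenyl on this carbon brings no gain over 2,4-dihydroxyphenyl, with a 2.2-fold higher number from compound 3 to compound 4 (0.34 log units; beyond the scatter). A halogen on this ring therefore does not by itself give the low number of compound 2, as a 9500-fold higher number from compound 2 to compound 4 (3.98 log units; beyond the scatter) shows, and the bromo compound also stands behind the simple 4-fluorophenyl, with a 12-fold higher number from compound 1 to compound 4 (1.09 log units; beyond the scatter). Both hydroxy-bearing compounds, compound 3 and compound 4, now lie above both fluorinated ones, and nothing at hand explains this split.

Open, from the compounds shown here alone, is whether 2-bromo-4-fluorophenyl would match 2-chloro-4-fluorophenyl. Also open, going by these compounds, is how 2-chloro-4-methoxyphenyl would stand.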